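Chloro in place of hydrogen on the phenyl of compound 3

A few compounds are considered here, and "the series" means these few. Any claim that something is new, unique, unknown or untested is made for them only; others in the source may bear on it.

The compounds measured so far:
Compound 1 `CC(C)(C)c1ccc(-c2nnc(SCCCN3CCN(c4ccccc4)CC3)[nH]2)cc1` reaches only the limit > 300000 nM in a functional assay on MCF7 cells (Homo sapiens) for cytotoxicity, read by MTT assay, with a stated time of 24 h; on this read-out higher numbers stand for weaker inhibition and lower numbers for stronger inhibition.
Compound 2 `Cc1ccc(-c2nnc(SCCCN3CCN(c4cccc(Cl)c4)CC3)[nH]2)cc1` also stops at the limit > 300000 nM in this assay.
Compound 3 `CC(C)(C)c1ccc(-c2nn(CCCN3CCN(c4ccccc4)CC3)c(=S)[nH]2)cc1` likewise gives only the limit > 300000 nM in this assay.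

Compound 3 therefore stands where every value of this assay stands: none of the three compounds gives a number, each is reported only as a limit, as stated by the limit of > 300000 nM in this assay, at which 3 of the 3 values shown sit. Going by the values given here, compound 1 and compound 2 show the same limit as compound 3, so there is no measured step anywhere in this set that could be read for size or direction.

Compound 4 `CC(C)(C)c1ccc(-c2nn(CCCN3CCN(c4cccc(Cl)c4)CC3)c(=S)[nH]2)cc1` differs from compound 3 in one place: chloro in place of hydrogen on an aromatic carbon. Among the compounds with values here, no pair of measured compounds covers this particular change, so nothing measured tells how large a step to expect. With all three values sitting at the limit of this assay, the expectation is no step beyond the scatter, and most likely another limit. Compound 4 is expected at 300000 nM in this assay, with a range from 100000 nM to 1000000 nM. The step from compound 3 to compound 4 is estimated as a number no higher from compound 3 to compound 4 (the limit leaves the size open).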

Compound 4, half-maximal inhibitory concentration: > 300000 nM
Compound 4 ended at the assay's limit; the forecaster's own chance of this, stated with the estimate: 80%; the middle value sits exactly at the limit.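

No step can be read from compound 3 to compound 4 in this assay, since both compounds are reported only as a limit: the limit of > 300000 nM in this assay, at which 4 of the 4 values shown sit. The compounds shown leave open whether chloro in place of hydrogen on the phenyl has any effect, and whether any compound of this kind would give a measured number rather than a limit in this assay at all.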